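This account rests on a few compounds, and the source may have more. Where it says the series, first, only, none or still open, it means among the compounds named here.

Compound 1 `Fc1cccc(-c2nc(Nc3ccccc3)c3ccccc3n2)c1`, compound 2 `COc1ccccc1Nc1nc(-c2cccc(F)c2)nc2ccc(F)cc12` and compound 3 `Fc1cccc(Nc2nc(-c3cccc(F)c3)nc3ccc(F)cc23)c1` share one core and differ only in the groups hung on it. All three were tested in a functional assay on U2OS cells (Homo sapiens) for cytotoxicity, read by MTT assay, with a stated time of 48 h; a lower number here means a stronger inhibitor, a higher number a weaker inhibitor. Compound 1 gives only a limit of the assay there, > 50000 nM, and no number. Compound 2 likewise gives only a limit in this assay, > 50000 nM. Compound 3 gives 49600 nM in this assay, and the step of a number no higher from compound 2 to compound 3 (the limit leaves the size open) therefore has a size that cannot be read. Among the values shown, compound 2 stands at the limit, and the limit of > 50000 nM in this assay, at which 2 of the 3 values shown sit, shows that this is where two of the three values sit.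

Compound 4 `Fc1cccc(-c2nc(Nc3ccccc3F)c3cc(F)ccc3n2)c1` has not yet been measured in this assay. It differs from compound 2 by fluoro in place of methoxy on an aromatic carbon, ortho to a large group. For the measured compounds named here, the single measured step that bears on this, from compound 2 to compound 3, swaps a group on the same ring and leaves the value at the same level, with no size readable. No step beyond the scatter is therefore expected from compound 2 to compound 4, a number no higher from compound 2 to compound 4 (the limit leaves the size open). Compound 4 is accordingly expected to give 50000 nM in this assay, between 20000 nM and 120000 nM, most probably again reported only as a limit.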

Compound 4, half-maximal inhibitory concentration: > 50000 nM
Compound 4: only a limit was reported (the forecaster's own chance of this, stated with the estimate: 70%); the middle value lies on the limit itself.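

In this assay compound 4 gives > 50000 nM, which is a limit of the assay and not a number. The data therefore give a number no lower from compound 3 to compound 4 (the limit leaves the size open). The step from compound 2 to compound 4 cannot be read in size either. What this adds is that 2-fluorophenyl on the nitrogen, in place of the 2-methoxyphenyl of compound 2, does not bring the compound to a readable value, so the swap from methoxy to fluoro at this place only adds another compound to the top of the range: the limit of > 50000 nM in this assay, at which 3 of the 4 values shown sit.

Only compound 3 gives a number, 49600 nM, so the compounds shown do not tell how far a group on this ring can move the value in this cell assay, if at all. As far as these compounds go, how an amine, a carboxylic acid or a longer chain at this place would read remains open.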